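Moving the Chlorine on the Ring of Compound 2

The source may hold more compounds than are shown below. What is called first, only, known or untested is meant among the compounds shown, and "the series" means these compounds.

In a functional assay on OVCAR-3 cells (Homo sapiens) for antiproliferative activity, read by MTT assay, with a stated time of 24 h (a lower number here means a stronger inhibitor, a higher number a weaker inhibitor), compound 2 `O=c1[nH]cc(S(=O)(=O)Nc2cccc(-c3cn(-c4cccc(Cl)c4)nn3)c2)c(=O)[nH]1` gives 3410 nM, the lowest of the two numbers, with compound 1 `Cc1ccc(-n2cc(-c3cccc(NS(=O)(=O)c4c[nH]c(=O)[nH]c4=O)c3)nn2)cc1` nearest at 3540 nM. Within the data shown here, the one earlier step on that aromatic nitrogen, a 1.0-fold lower number from compound 1 to compound 2 (0.02 log units; within the scatter), exchanged one aryl group for another and stayed within the scatter. Compound 3 `O=c1[nH]cc(S(=O)(=O)Nc2cccc(-c3cn(-c4ccc(Cl)cc4)nn3)c2)c(=O)[nH]1` differs from compound 2 by 4-chlorophenyl in place of 3-chlorophenyl on an aromatic nitrogen; the two have the same atoms, joined differently. With only a step within the scatter to draw on, the expected step in this assay is a 1.0-fold lower number from compound 2 to compound 3 (0.00 log units; within the scatter), none beyond the scatter. Compound 3 is therefore estimated at 3400 nM, between 1500 nM and 7500 nM.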

Compound 3, half-maximal inhibitory concentration: 2040 nM
The estimate for compound 3 lay 1.7-fold (0.22 log units) above the measured number; the range from low to high includes it.
By their numbers in this assay, from the lowest: compounds 3, 2 and 1 (each within the scatter of the next).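

In this assay the shift from 3-chlorophenyl to 4-chlorophenyl on the aromatic nitrogen gave a 1.7-fold lower number from compound 2 to compound 3 (0.22 log units; within the scatter) and showed that placing the chlorine differently on this ring, not only exchanging one aryl group for another, stays within the scatter. Chloro in place of methyl on an aromatic carbon, a change the earlier pair did not offer, gave a 1.7-fold lower number from compound 1 to compound 3 (0.24 log units; within the scatter) and also stayed within it. No measurement shown here accounts for the size of these steps. The compounds leave open whether an amine, a carboxylic acid or a longer chain on this phenyl ring would give a step beyond the scatter.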